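Fluoro in Place of Methoxy: What Compound 4 Should Tolerate

The source may hold more compounds than are shown below. What is called first, only, known or untested is meant among the compounds shown, and "the series" means these compounds.

Compound 1, `COc1ccc(/C=N/NC(=O)c2ccc(C)cc2O)cc1`: 723000 nM
Compound 2, `Cc1ccc(C(=O)N/N=C/c2cc(Cl)cc(Cl)c2O)c(O)c1`: 708000 nM
Compound 3, `Cc1ccc(C(=O)N/N=C/c2ccccc2O)c(O)c1`: 761000 nM

Of the compounds shown here, three sharing one core have been tested in an ADME assay on cells (Mus musculus, strain BALB/C) for cytotoxicity, read by MTT assay, with a stated time of 24 h; a higher number here means that more compound is tolerated, a lower number that less compound is tolerated. Compound 1 gives 723000 nM, compound 2 gives 708000 nM, and compound 3 gives 761000 nM. Compound 1 stands second highest of the three numbers, but its nearest neighbour, compound 2, lies within the scatter of it, and so does compound 3, the furthest of the set. On these numbers the three compounds cannot be told apart: the substitution pattern on the aldehyde-derived ring has left the tolerated concentration essentially unchanged across the set.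

Compound 4, `Cc1ccc(C(=O)N/N=C/c2ccc(F)cc2)c(O)c1`, has not yet been measured. It differs from compound 1 in one place: fluoro in place of methoxy on an aromatic carbon. For the measured compounds named here, no step between two measured compounds is available for this change. Given that compounds 1, 2 and 3 all sit within the scatter of one another despite carrying quite different groups on that ring, the step from compound 1 to compound 4 in this assay is expected to be none beyond the scatter, in either direction. Compound 4 is therefore estimated to give 720000 nM, within a range of 450000 nM to 1150000 nM, which means an expected step of a 1.0-fold lower number from compound 1 to compound 4 (0.00 log units; within the scatter).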

Compound 4, half-maximal cytotoxic concentration: 568000 nM
Beside the measured number, compound 4's estimate is 1.3-fold (0.10 log units) above it, and the stated range covers the measured number.
By their numbers in this assay, from the lowest: compounds 4, 2, 1 and 3 (each within the scatter of the next).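

In this assay, for the compounds shown here, the one step read directly at this position is a 1.3-fold lower number from compound 1 to compound 4 (0.10 log units; within the scatter) for fluoro in place of methoxy, on an aromatic carbon para to a large group. The earlier compounds shown here offered no pair differing in one place, so their closeness could only hint at how this position behaves, whereas this pair isolates a single change: a methoxy with its hydrogen-bond acceptor leaves, a lone fluorine enters, and compound 4 cannot be told apart from compound 1 in how much is tolerated. Nothing at hand bears on why the step has this size.

Whether this position stays as undemanding for groups of another kind remains open: an amine, a carboxylic acid or a longer chain such as butoxy on that aromatic carbon could read quite differently in this assay from anything shown here. On these data alone, it is also open whether fluoro in place of methoxy would give a step of similar size at another aromatic carbon of the shared core.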